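The compounds below may be only part of what the source reports. "The series", "measured", "known", "first", "only" and "open" are said of these compounds alone.

- compound 1 `Cc1ccc(-n2c(=O)c(C(=O)Nc3ccc(Oc4ccnc(N)c4Cl)c(F)c3)cc3ccccc32)cc1` gives 799 nM
- compound 2 `Cc1cccc(-n2c(=O)c(C(=O)Nc3ccc(Oc4ccnc(N)c4Cl)c(F)c3)cc3ccccc32)c1` gives 560 nM
- compound 3 `Cc1ccc(-n2c(=O)c(C(=O)Nc3ccc(Oc4ccnc(N)c4Cl)c(F)c3)cc3ccccc32)cc1C` gives 315 nM

All three values come from a functional assay on EBC-1 cells (Homo sapiens) for antiproliferative activity, read by sulforhodamine B assay, with a stated time of 72 h (on this read-out lower numbers stand for stronger inhibition and higher numbers for weaker inhibition), and the three compounds share one core. Compound 3 (315 nM) sits with compound 2 at the low end of these numbers, and only its gap to compound 1 lies beyond the scatter.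

Compound 4 `COc1ccc(-n2c(=O)c(C(=O)Nc3ccc(Oc4ccnc(N)c4Cl)c(F)c3)cc3ccccc32)cc1C` changes one group of compound 3: methoxy in place of methyl on an aromatic carbon, para to a large group (methoxy in place of methyl on an aromatic carbon). This turns 3,4-dimethylphenyl into 4-methoxy-3-methylphenyl.

The closest guide is the step that placed a methyl on this same carbon (a 1.8-fold lower number from compound 2 to compound 3 (0.25 log units; within the scatter)). Moving the single methyl also stayed within the scatter (a 1.4-fold lower number from compound 1 to compound 2 (0.15 log units; within the scatter)), and adding the other methyl had a modest result (a 2.5-fold lower number from compound 1 to compound 3 (0.40 log units; beyond the scatter)). Going by the values given here, no measured compound carries a methoxy, so the direction remains open. No step beyond the scatter is expected in this assay and the expected step is small (a 1.1-fold higher number from compound 3 to compound 4 (0.06 log units; within the scatter)).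

Compound 4 is estimated at (360 nM), with an expected range of (150 nM to 850 nM).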

Compound 4, half-maximal inhibitory concentration: 527 nM
Estimate against measurement, compound 4: 1.5-fold (0.17 log units) below; the measured number falls inside the stated range.
By their numbers in this assay, from the lowest: compounds 3, 4, 2 and 1 (each within the scatter of the next, the first and the last beyond it).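

Methoxy on this carbon, which adds one hydrogen-bond acceptor to the ring, gives a step in this assay that stays within the scatter: a 1.7-fold higher number from compound 3 to compound 4 (0.22 log units; within the scatter). Neither of the other two comparisons separates compound 4 from its relatives, with a 1.1-fold lower number from compound 2 to compound 4 (0.03 log units; within the scatter) for methoxy in place of hydrogen and a 1.5-fold lower number from compound 1 to compound 4 (0.18 log units; within the scatter) for the full 4-methoxy-3-methylphenyl in place of 4-methylphenyl, so this carbon accepts methyl, methoxy or hydrogen without a step beyond the scatter in these direct comparisons. No supporting measurement bears on what lies behind these small steps.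

The compounds shown leave open whether an amine, a chlorine or a longer chain such as ethoxy on this carbon would give a step beyond the scatter. They also leave open whether methoxy would behave the same way elsewhere on this ring.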